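Replacing the 3-fluoro-4-hydroxyphenyl group of compound 3

A few compounds are considered here, and "the series" means these few. Any claim that something is new, unique, unknown or untested is made for them only; others in the source may bear on it.

In a functional assay on A549 cells (Homo sapiens) for antiproliferative activity, read by sulforhodamine B assay, with a stated time of 48 h (on this read-out lower numbers stand for stronger inhibition and higher numbers for weaker inhibition), compound 1 (`COc1ccc(OC)c(/C=C/C(=O)C(=Cc2ccc(O)c(OC)c2)C(=O)/C=C/c2cc(OC)ccc2OC)c1`) gives 190 nM and compound 2 (`COc1ccc(OC)c(/C=C/C(=O)C(=Cc2ccc(OC)c(OC)c2)C(=O)/C=C/c2cc(OC)ccc2OC)c1`) gives 400 nM while compound 3 (`COc1ccc(OC)c(/C=C/C(=O)C(=Cc2ccc(O)c(F)c2)C(=O)/C=C/c2cc(OC)ccc2OC)c1`) gives 220 nM on the same scale. Compound 3 stands within the scatter of both others. Compound 4 (`COc1ccc(OC)c(/C=C/C(=O)C(=Cc2cc(OC)c(O)c(OC)c2)C(=O)/C=C/c2cc(OC)ccc2OC)c1`) carries 4-hydroxy-3,5-dimethoxyphenyl in place of 3-fluoro-4-hydroxyphenyl (4-hydroxy-3,5-dimethoxyphenyl in place of 3-fluoro-4-hydroxyphenyl on a double-bonded chain carbon bound to a double-bonded chain carbon) on a double-bonded chain carbon bound to a double-bonded chain carbon. Fluoro in place of methoxy made little difference (a 1.2-fold higher number from compound 1 to compound 3 (0.06 log units; within the scatter)) while methyl in place of the hydroxy hydrogen gave a modest step (a 2.1-fold higher number from compound 1 to compound 2 (0.32 log units; beyond the scatter)) that compound 4 does not repeat. Compound 4 keeps the hydroxy group, so the expected change is small (a 1.1-fold higher number from compound 3 to compound 4 (0.06 log units; within the scatter)) and within the scatter. The estimate for compound 4 is 250 nM with an expected range from 100 nM to 600 nM on this read-out.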

Compound 4, half-maximal inhibitory concentration: 190 nM
The estimate for compound 4 lay 1.3-fold (0.12 log units) above the measured number; measured number inside the range.
By their numbers in this assay, from the lowest: compounds 1, 4, 3 and 2 (each within the scatter of the next, the first and the last beyond it).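

In this assay, adding a further methoxy to the ring that keeps its hydroxy group changes nothing (no change at the digits printed from compound 1 to compound 4 (within the scatter)), and 4-hydroxy-3,5-dimethoxyphenyl can stand in for 3-fluoro-4-hydroxyphenyl with the step staying within the scatter (a 1.2-fold lower number from compound 3 to compound 4 (0.06 log units; within the scatter)). Set against 3,4-dimethoxyphenyl, the same group gives a modest step beyond the scatter (a 2.1-fold lower number from compound 2 to compound 4 (0.32 log units; beyond the scatter)), so compound 2, the only compound without a hydroxy group, stands apart from compound 1 and compound 4, though not from compound 3. No measurement shown here accounts for these steps. As far as these compounds go, whether an amine or a carboxylic acid could take the place of the hydroxy group on this ring remains open.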